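The source may hold more compounds than are shown below. What is called first, only, known or untested is meant among the compounds shown, and "the series" means these compounds.

Measured so far:
compound 1 `O=C(Nc1ccc(Cl)c(C(F)(F)F)c1)Nc1cccc2c(O)cccc12` — 45 nM
compound 2 `O=C(Nc1ccc(Cl)c(C(F)(F)F)c1)Nc1cccc2ccc(C(=O)O)cc12` — 84 nM

Both compounds were tested in an in vitro functional assay on cells for antagonist activity at transient receptor potential cation channel subfamily V member 1 (Homo sapiens), read by reporter gene assay and calcium flux; on this read-out higher numbers stand for weaker inhibition and lower numbers for stronger inhibition. Compound 1 gives 45 nM there, and compound 2 gives 84 nM. Among the measured compounds shown here, compound 2 is one of only two measured compounds, and its value and that of compound 1 lie within the usual scatter of each other, so the two cannot be told apart on these numbers. For the measured compounds named here, no step between measured compounds is recorded, and nothing about the move from a hydroxy to a carboxy substituent on the core can be read as a trend.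

The next compound, compound 3 `CS(=O)(=O)Nc1ccc2cccc(NC(=O)Nc3ccc(Cl)c(C(F)(F)F)c3)c2c1`, differs from compound 2 in a single place: methanesulfonamido in place of carboxy on an aromatic carbon. The shared urea and the chloro-trifluoromethylphenyl part remain untouched. Going by the values given here, with only two measured points and no matched step to lean on, the expected size of the change in this assay is no more than the scatter, with no clear direction. Compound 3 is therefore expected to land near compound 2, at an estimated 55 nM (range 15 nM to 200 nM), which means an expected step of a 1.5-fold lower number from compound 2 to compound 3 (0.18 log units; within the scatter).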

Compound 3, half-maximal inhibitory concentration: > 1000 nM
Compound 3: no number, only a limit; the forecaster's own chance of this, stated with the estimate: 5%; middle value at least 18-fold (1.25 log units) from the limit.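

For compound 3 the read-out in this assay is a limit of the assay and not a number: the limit of > 1000 nM in this assay, at which 1 of the 3 values shown sits. Even so, methanesulfonamido in place of carboxy on this aromatic carbon gives an at least 11-fold higher number from compound 2 to compound 3 (1.07 log units; beyond the scatter), so what sits at this position can matter in this assay, which the two earlier compounds, with no step between them, could not show. The counted differences are that the entering group has more heavy atoms, brings in nitrogen and sulfur and has more hydrogen-bond acceptors, while the hydrogen-bond donor count and the absence of a net charge stay the same, so neither of those two unchanged counts accompanies the step as a difference.

From the compounds shown here alone, this single step cannot separate the contributions of the sulfur, the nitrogen and the overall size of the entering group, and the true value of compound 3 stays unknown beyond its limit. A simple amine, a primary carboxamide or a methyl sulfone on the same aromatic carbon would each bear on that question, as the shown compounds leave open which feature of methanesulfonamido goes with the step.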